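The source may hold more compounds than are shown below. What is called first, only, known or untested is meant among the compounds shown, and "the series" means these compounds.

Measured compounds:
compound 1 `CNc1ncnc2c1c(I)cn2[C@@H]1O[C@H](CO)[C@@H](O)[C@H]1O`, in a functional assay on K562 cells (Homo sapiens), read by MTT assay, with a stated time of 72 h (on this read-out higher numbers stand for weaker inhibition and lower numbers for stronger inhibition), compound 1 gives > 100000 nM, which is a limit and not a number.
compound 2 `COc1ncnc2c1c(I)cn2[C@@H]1O[C@H](CO)[C@@H](O)[C@H]1O`, in this assay compound 2 gives > 20000 nM, also a limit and not a number.
compound 3 `CNc1ncnc2c1c(-c1ccco1)cn2[C@@H]1O[C@H](CO)[C@@H](O)[C@H]1O`, in this assay compound 3 gives 220 nM.

The cores of compound 1 and compound 3 differ by furan-2-yl in place of iodo on an aromatic carbon, a change that gives an at least 450-fold lower number from compound 1 to compound 3 (2.65 log units; beyond the scatter). Compound 2 differs from compound 1 by methoxy in place of methylamino on an aromatic carbon, and the step is a step that the two limits leave unreadable from compound 1 to compound 2.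

Compound 4 `COc1ncnc2c1c(-c1ccco1)cn2[C@@H]1O[C@H](CO)[C@@H](O)[C@H]1O` is not yet measured. It differs from compound 3 by methoxy in place of methylamino on an aromatic carbon, the same change as from compound 1 to compound 2, at the same place. Since that earlier step is not readable, the expectation for this assay rests on compound 3 alone, with a step of a 4.5-fold higher number from compound 3 to compound 4 (0.66 log units; beyond the scatter) expected. Compound 4 is estimated at 1000 nM, expected between 200 nM and 10000 nM.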

Compound 4, half-maximal inhibitory concentration: 60 nM
For compound 4 the middle estimate is 17-fold (1.22 log units) above the measured one; measured number outside the range, below it.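

Furan-2-yl in place of iodo gives an at least 330-fold lower number from compound 2 to compound 4 (2.52 log units; beyond the scatter), so in this assay the large drop seen on the methylamino core also appears on the methoxy core. The two sizes cannot be separated: the same change on two cores in this assay, an at least 450-fold lower number (2.65 log units; beyond the scatter) from compound 1 to compound 3 and an at least 330-fold lower number (2.52 log units; beyond the scatter) from compound 2 to compound 4; the limit leaves it open whether they differ

Methoxy in place of methylamino gives a 3.7-fold lower number from compound 3 to compound 4 (0.56 log units; beyond the scatter) on the furan-2-yl core, but the corresponding step between the two iodo compounds cannot be read, as both values are limits, so the data do not show whether this change carries across cores.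

Still open, going by these compounds, is whether a thiophen-2-yl or phenyl group in place of furan-2-yl would give a similar number. Also open, on these data alone, is how an ethoxy group or a dimethylamino group would compare with methoxy on the core of compound 4.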